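The source may report more compounds than this note shows. Statements on the series, on what has been measured and on what is new or still open speak of the compounds shown alone.

Working notes on the series. Among the measured compounds shown here, compound 2 `O=C(CN1CCN(c2cc3c(cc2F)c(=O)c(C(=O)O)cn3C2CC2)CC1)Nc1ccc(C(=O)/C=C/c2cccc(Cl)c2)cc1` gives the higher of the two numbers so far in a physicochemical assay for solubility, at pH 6.9; a higher number here means a more soluble compound, a lower number a less soluble compound: compound 2 reads 34.4 ug/mL, while compound 1 `O=C(CN1CCN(c2cc3c(cc2F)c(=O)c(C(=O)O)cn3C2CC2)CC1)Nc1ccc(C(=O)/C=C/c2ccccc2Cl)cc1` reads 2.45 ug/mL. For the measured compounds named here, the one step that joins them, a 14-fold higher number from compound 1 to compound 2 (1.15 log units; beyond the scatter), is the only measured step in the set.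

Compound 3 `COc1ccc(/C=C/C(=O)c2ccc(NC(=O)CN3CCN(c4cc5c(cc4F)c(=O)c(C(=O)O)cn5C4CC4)CC3)cc2)cc1` is not yet measured in this assay. Its change from compound 2 is 4-methoxyphenyl in place of 3-chlorophenyl on a double-bonded chain carbon bound to a double-bonded chain carbon. Going by the values given here, no measured step covers this change: the step from compound 1 to compound 2 moves a chlorine around the ring, whereas here the chlorine-bearing ring leaves altogether and a ring carrying a methoxy group enters. That step shows the aryl group at this position can shift the number by a large amount, but it gives no direction for the present exchange.

Compound 3 is therefore expected to sit close to compound 2, with a step of a 1.4-fold lower number from compound 2 to compound 3 (0.14 log units; within the scatter) and wide uncertainty either way. For compound 3 the estimate in this assay is 25 ug/mL, ranging from 5 ug/mL to 90 ug/mL.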

Compound 3, solubility: 2.98 ug/mL
Compound 3: middle estimate off by 8.4-fold (0.92 log units), on the high side; the whole stated range lies above it.
By their numbers in this assay, from the lowest: compounds 1 and 3 (each within the scatter of the next); then compound 2.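

In this assay, replacing 3-chlorophenyl with 4-methoxyphenyl costs as much as moving the chlorine did (a 12-fold lower number from compound 2 to compound 3 (1.06 log units; beyond the scatter)), so the exchange of aryl groups at this position is not a neutral one. Compound 3 and compound 1 cannot be told apart (a 1.2-fold higher number from compound 1 to compound 3 (0.09 log units; within the scatter)), which leaves compound 2 alone at the high end among the three aryl groups, with two quite different rings reading alike at the low end. Nothing available here bears on why the numbers differ.

Still open, going by these compounds, is whether the high number of compound 2 goes with the chlorine itself or with where it sits, since chlorine and methoxy are never compared at the same ring place. Also open, on these data alone, is how a ring bearing an amine or a carboxylic acid would read here.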